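A few compounds are considered here, and "the series" means these few. Any claim that something is new, unique, unknown or untested is made for them only; others in the source may bear on it.

Measured so far:
- compound 1, `Cn1c(SCc2ccccc2)nnc1-c1cc([N+](=O)[O-])cc([N+](=O)[O-])c1`: in an ADME assay on A-431 cells (Homo sapiens) for cytotoxicity, with a stated time of 48 h (a lower number here means a stronger inhibitor, a higher number a weaker inhibitor), compound 1 gives > 30000 nM, which is a limit of the assay, not a number.
- compound 2, `CCCCCCn1c(SCc2ccccc2)nnc1-c1cc([N+](=O)[O-])cc([N+](=O)[O-])c1`: compound 2 gives > 30000 nM, again a limit.
- compound 3, `O=[N+]([O-])c1cc(-c2nnc(SCc3ccccc3)n2Cc2ccccc2)cc([N+](=O)[O-])c1`: compound 3 gives > 30000 nM, again a limit.

Compound 3 therefore stands nowhere distinct: all three measured values sit at the limit of > 30000 nM in this assay, at which 3 of the 3 values shown sit. The steps among the measured compounds, a step that the two limits leave unreadable from compound 1 to compound 2, a step that the two limits leave unreadable from compound 1 to compound 3 and a step that the two limits leave unreadable from compound 2 to compound 3, are all unreadable for the same reason, and all of them concern the saturated chain carbon bound to an aromatic nitrogen.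

Compound 4, `CCCSc1nnc(-c2cc([N+](=O)[O-])cc([N+](=O)[O-])c2)n1Cc1ccccc1`, differs from compound 3 by ethyl in place of phenyl on a saturated chain carbon bound to a sulfur. Going by the values given here, no measured step touches the saturated chain carbon bound to a sulfur, so no size or direction can be read from the series for this change. Among the compounds with values here, the only guide is that every compound measured so far returned a limit. Compound 4 is therefore expected to give 40000 nM, within 12000 nM to 120000 nM, most likely again reported as a limit. The expected step that the limit leaves unreadable from compound 3 to compound 4 is thus an estimate of no change beyond the scatter.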

Compound 4, half-maximal inhibitory concentration: > 30000 nM
Compound 4: no number, only a limit; the forecaster's own chance of this, stated with the estimate: 80%; the middle value is on the limit's open side.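

In this assay compound 4 gives > 30000 nM, a limit and not a number, so no step can be read between compound 3 and compound 4: the limit of > 30000 nM in this assay, at which 4 of the 4 values shown sit.

The compounds shown leave open whether any change on the saturated chain carbons, bound to an aromatic nitrogen or to a sulfur, alters the read-out at all.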